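Chloro on the benzoyl ring: expectation for compound 4

A few compounds are considered here, and "the series" means these few. Any claim that something is new, unique, unknown or untested is made for them only; others in the source may bear on it.

Measured compounds:
compound 1 `O=C(Nc1ccccc1O)C1CCc2ccccc2N1C(=O)c1ccccc1Cl`; in a functional assay on MDA-MB-231 cells (Homo sapiens) for cytotoxicity, read by sulforhodamine B assay, with a stated time of 72 h (on this read-out lower numbers stand for stronger inhibition of growth and higher numbers for weaker inhibition of growth), compound 1 gives 47400 nM
compound 2 `O=C(Nc1ccccc1O)C1CCc2ccccc2N1C(=O)c1ccccc1`; compound 2 gives 4210 nM
compound 3 `O=C(Nc1cc(C(F)(F)F)cc(C(F)(F)F)c1)C1CCc2ccccc2N1C(=O)c1ccccc1`; compound 3 gives 2430 nM

Compound 3 has the lowest of the three numbers in this assay; its value and that of compound 2 lie within the scatter of each other, while compound 1 stands well apart from both. The difference between the core of compound 2 and the core of compound 3 is not broken down here.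

Compound 4 `O=C(Nc1cc(C(F)(F)F)cc(C(F)(F)F)c1)C1CCc2ccccc2N1C(=O)c1cccc(Cl)c1` is not yet measured. It differs from compound 3 by chloro in place of hydrogen on an aromatic carbon

The same kind of change is already measured once, from compound 2 to compound 1: chloro in place of hydrogen on an aromatic carbon That step gave an 11-fold higher number from compound 2 to compound 1 (1.05 log units; beyond the scatter) in this assay. The two places are not the same: in compound 1 the chloro sits ortho to a large group, in compound 4 meta to a large group, and the cores carry different amide substituents, so the earlier step is only a loose guide.

For compound 4 a weaker rise than the earlier one is expected, a 2.1-fold higher number from compound 3 to compound 4 (0.31 log units; beyond the scatter), because the earlier step of an 11-fold higher number from compound 2 to compound 1 (1.05 log units; beyond the scatter) was large but came from a different place and a different core. The estimated value for compound 4 in this assay is 5000 nM, with a range from 1800 nM to 16000 nM.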

Compound 4, concentration for 50% growth inhibition: 1190 nM
Beside the measured number, compound 4's estimate is 4.2-fold (0.62 log units) above it; the measured number lies below the stated range.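

In this assay, chloro in place of hydrogen on the benzoyl ring gives a 2.0-fold lower number from compound 3 to compound 4 (0.31 log units; beyond the scatter) and so does not repeat the direction or size of the earlier step, as the two measurements of this change show: the same change on two cores in this assay, an 11-fold higher number (1.05 log units; beyond the scatter) from compound 2 to compound 1 and a 2.0-fold lower number (0.31 log units; beyond the scatter) from compound 3 to compound 4, 23-fold (1.36 log units) apart, beyond the scatter of two such steps

This shows that, within this series, the step measured on one core cannot be carried as a number or even as a direction to another core. It does not show what separates the two outcomes, since compound 1 and compound 4 differ in both the place of the chloro on the benzoyl ring and the amide substituent, and each outcome rests on a single pair of compounds.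

The compounds shown leave open whether the two steps would converge with the chloro at one place on both cores, which would take the 3-chlorophenyl group on the core of compound 2 and the chloro placement of compound 1 on the core of compound 3. Also open, from the compounds shown here alone, is whether a bromo, methoxy, amine or carboxylic acid group at the place of the chloro in compound 4 would shift the number in the same direction.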